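Aryl ether to methyl ether on the pyridine-bearing core

A few compounds are considered here, and "the series" means these few. Any claim that something is new, unique, unknown or untested is made for them only; others in the source may bear on it.

Measured compounds:
compound 1 `CN1CC2C=C(c3cncc(C#N)c3)CC(C2)C1`: 4500 nM
compound 2 `Clc1ccc(Oc2cncc(C3=CC4CNCC(C3)C4)c2)cc1`: 40 nM
compound 3 `C1=C(c2ccc(-c3ccccc3)nc2)CC2CNCC1C2`: 507 nM

In an in vitro assay on SH-SY5Y cells for displacement of a labelled ligand from Neuronal acetylcholine receptor; alpha3/beta4 (Homo sapiens) (a lower number here means a stronger inhibitor, a higher number a weaker inhibitor), compound 2 gives 40 nM, the lowest of the three numbers and thus the strongest inhibitor here; compound 3 gives 507 nM and compound 1 gives 4500 nM, both steps from compound 2 lying beyond the scatter. For the measured compounds named here, no two measured compounds differ in one place only, so no measured step is available for any single change.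

Compound 4 `COc1cncc(C2=CC3CNCC(C2)C3)c1` is the next compound to be measured. It differs from compound 2 by the change (methyl in place of 4-chlorophenyl on an oxygen on an aromatic ring). The change removes most of what distinguishes compound 2 from the other two in size, and the other two give higher numbers. A step upward in this assay from compound 2 to compound 4 is therefore expected, beyond the scatter, of the order of a 15-fold higher number from compound 2 to compound 4 (1.18 log units; beyond the scatter). For compound 4 the estimate is 600 nM, with a range from 150 nM to 3000 nM.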

Compound 4, inhibition constant: 14.3 nM
Beside the measured number, compound 4's estimate is 42-fold (1.62 log units) above it; the whole stated range lies above it.
By their numbers in this assay, from the lowest: compound 4; then compound 2; then compound 3; then compound 1.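

In this assay, methyl in place of 4-chlorophenyl on an oxygen on an aromatic ring gives a 2.8-fold lower number from compound 2 to compound 4 (0.45 log units; beyond the scatter), a modest step. The low number of compound 2 therefore does not depend on the 4-chlorophenyl, since the much smaller methyl, with no ring, still gives a lower number at this position. The earlier compounds could not show this, as none of them differed from another in one place only, and nothing measured here explains the direction of the step.

As far as these compounds go, it remains open whether a longer chain, such as ethyl or propyl, on the same oxygen would hold the number at this level, or whether an amine in place of the oxygen would do so. Compound 1 and compound 3 differ from compound 4 in more than one place, so those steps cannot be read.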